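Ester to acid on the bromo-substituted core: compound 4

This account rests on a few compounds, and the source may have more. Where it says the series, first, only, none or still open, it means among the compounds named here.

The series shares the core seen in compound 1 `O=C(O)CC1CNC(=O)c2cc(Br)c(Br)n21`. In a functional assay on PC-3 cells (Homo sapiens) for cytotoxicity, read by CCK-8 assay, with a stated time of 72 h (on this read-out lower numbers stand for stronger inhibition and higher numbers for weaker inhibition), compound 1 gives only a limit, > 200000 nM. Compound 2 `COC(=O)CC1CNC(=O)c2cccn21` also gives only a limit in this assay, > 200000 nM. Among the compounds with values here, compound 3 `COC(=O)CC1CNC(=O)c2ccc(Br)n21` is the one member with a measured number: in this assay compound 3 gives 70000 nM. The remaining values in this assay are limits, (the limit of > 200000 nM in this assay, at which 2 of the 3 values shown sit). Within the data shown here, the single measured step, an at least 2.8-fold lower number from compound 2 to compound 3 (0.45 log units; beyond the scatter), concerns the bromo group and not the ester. Compound 4 `O=C(O)CC1CNC(=O)c2ccc(Br)n21` differs from compound 3 by hydrogen in place of methyl on an oxygen next to a carbonyl group. No measured step bears directly on this change; compound 1, which also carries a carboxy group, sits at a limit, while compound 3, carrying the methoxycarbonyl group, gives a number, but these two compounds differ in two places and no step between them is shown. A step towards a higher number, possibly back to a limit, is therefore expected for compound 4, a 2.1-fold higher number from compound 3 to compound 4 (0.33 log units; beyond the scatter). Compound 4 is expected at 150000 nM, between 50000 nM and 300000 nM.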

Compound 4, half-maximal inhibitory concentration: > 200000 nM
Compound 4: only a limit was reported; the forecaster's own chance of this, stated with the estimate: 55%; at least 1.3-fold (0.12 log units) between middle value and limit.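

In this assay, within the data shown here, hydrogen in place of methyl on an oxygen next to a carbonyl group gives an at least 2.8-fold higher number from compound 3 to compound 4 (0.45 log units; beyond the scatter), the first readable step for this change, and the size stands only as a bound, since compound 4 gives a limit and not a number. The step from compound 1 to compound 4 cannot be read, as both values are limits. Compound 3 therefore remains the only member with a measured number, with neither carboxy compound joining it and compound 2 showing that the methoxycarbonyl group alone does not give one: the limit of > 200000 nM in this assay, at which 3 of the 4 values shown sit.

As far as these compounds go, how weak compound 4 really is stays open. Also open, from the compounds shown here alone, is whether a primary amide or an ethyl ester in place of the methoxycarbonyl group would keep a measured number on the bromo-substituted core.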